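This account rests on a few compounds, and the source may have more. Where it says the series, first, only, none or still open, it means among the compounds named here.

Measured so far:
compound 1, `COc1cccc(CNCCCNc2ccnc3cc(Cc4ccc(C#N)cc4)ccc23)c1O`: in a physicochemical assay for solubility, with a stated time of 18 h, at pH 7.4 (on this read-out higher numbers stand for higher solubility and lower numbers for lower solubility), compound 1 gives 4200 nM
compound 2, `COc1cccc(CNCCCNc2ccnc3cc(-c4ccc(F)cc4)ccc23)c1O`: in this assay compound 2 gives 32000 nM

For the measured compounds named here, of these two numbers, compound 2 holds the higher one; its only neighbour is compound 1, and the step between them, a 7.6-fold higher number from compound 1 to compound 2 (0.88 log units; beyond the scatter), shows that swapping the group at this position of the shared core moves solubility by a clear margin. Compound 3, `COc1cccc(CNCCCNc2ccnc3cc(Oc4ccc(C(C)(C)C)cc4)ccc23)c1O`, has not yet been measured. It differs from compound 2 in one place: 4-(tert-butyl)phenoxy in place of 4-fluorophenyl on an aromatic carbon. Going by the values given here, only the step from compound 1 to compound 2 bears on this, and it concerns the same position but different groups, so it speaks to how sensitive this position is rather than to the direction for compound 3. The incoming group carries more heavy atoms than the one it replaces, and it adds a hydrogen-bond acceptor, so the two pointers do not agree. Taken together, compound 3 is expected to show a lower number in this assay, a step of about a 4.0-fold lower number from compound 2 to compound 3 (0.60 log units; beyond the scatter), with wide uncertainty. The estimate for compound 3 is 8000 nM, within a range from 2000 nM to 40000 nM.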

Compound 3, solubility: 14500 nM
Estimate against measurement, compound 3: 1.8-fold (0.26 log units) below; the range from low to high includes it.
By their numbers in this assay, from the lowest: compound 1; then compound 3; then compound 2.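

Placing 4-(tert-butyl)phenoxy on this aromatic carbon instead of 4-fluorophenyl gives a 2.2-fold lower number from compound 2 to compound 3 (0.34 log units; beyond the scatter) in this assay, so a third group at this position also moves the read-out by more than the usual scatter. Set against the 4-cyanobenzyl group, the same change gives a 3.5-fold higher number from compound 1 to compound 3 (0.54 log units; beyond the scatter) and places compound 3 in the middle of the three, which shows that a group with more heavy atoms than 4-fluorophenyl can still keep the number well above that of compound 1. No measurement shown here explains this order of the three groups.

Going by these compounds, the change from compound 2 to compound 3 alters two things at once, adding an oxygen atom that links the rings and replacing fluorine with tert-butyl on the outer ring, so the share of each in the step remains open. A plain phenoxy group or a 4-fluorophenoxy group would help to separate the two, and a group carrying an amine or a carboxylic acid would test this position with a very different kind of substituent.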